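Swapping trifluoromethyl for chloro on the outer amide ring

This account rests on a few compounds, and the source may have more. Where it says the series, first, only, none or still open, it means among the compounds named here.

Measured compounds:
compound 1 `Nc1ncnc2c1ccn2-c1ccc(NC(=O)c2cccc(C(F)(F)F)c2)cc1` — 9700 nM
compound 2 `O=C(Nc1ccc(-n2ccc3c(NC(=O)c4ccccc4)ncnc32)cc1)c1ccc(Cl)c(C(F)(F)F)c1` — 2300 nM

In a functional assay on A375P cells (Homo sapiens) for antiproliferative activity, read by MTT assay, with a stated time of 24 h (on this read-out higher numbers stand for weaker inhibition and lower numbers for stronger inhibition), compound 1 gives 9700 nM, and compound 2 gives 2300 nM. Compound 2 therefore stands at the lower of the two measured numbers, with compound 1 lying higher by a gap that is beyond the usual scatter. Compound 3 `O=C(Nc1ccc(-n2ccc3c(NC(=O)c4ccccc4)ncnc32)cc1)c1ccc(Cl)c(Cl)c1` is not yet measured; it differs from compound 2 in one place only: chloro in place of trifluoromethyl on an aromatic carbon.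

Within the data shown here, no measured pair in this set shows this kind of exchange, so no step size can be read off from the data. With only the value of compound 2 as an anchor, the expectation is a small shift, most likely within the scatter, with a slight lean towards a higher number. Compound 3 is expected to give 3000 nM, in a range from 1200 nM to 8000 nM. This estimate amounts to a step of a 1.3-fold higher number from compound 2 to compound 3 (0.12 log units; within the scatter).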

Compound 3, half-maximal inhibitory concentration: 2000 nM
The estimate for compound 3 lay 1.5-fold (0.18 log units) above the measured number; the range from low to high includes it.
By their numbers in this assay, from the lowest: compounds 3 and 2 (each within the scatter of the next); then compound 1.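

In this assay, among these compounds, the change from 4-chloro-3-(trifluoromethyl)phenyl to 3,4-dichlorophenyl gives the first step in this set that concerns a single place (a 1.2-fold lower number from compound 2 to compound 3 (0.06 log units; within the scatter)), and this step lies within the usual scatter. At this place on the ring, ortho to a chloro group, the read-out therefore does not separate trifluoromethyl from chloro, even though chloro has fewer heavy atoms, so trifluoromethyl is not required for a value in this range. No accompanying measurement bears on why the two groups read alike.

This single exchange does not show how far that tolerance extends, since a bare hydrogen, a methoxy group, an amine or a carboxylic acid at the same place could read quite differently. Going by these compounds, compound 1 differs from compound 2 in more than one place, so the effect of each of those differences remains open.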